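Pyridin-2-yl in place of phenyl: clearance notes

The source may report more compounds than this note shows. Statements on the series, on what has been measured and on what is new or still open speak of the compounds shown alone.

Of the compounds shown here, three sharing one core have been measured in an ADME assay on the whole organism (Rattus norvegicus, strain Sprague-Dawley) for pharmacokinetics, at a dose of 0.5 mg/kg by the intravenous route; a lower number here means slower removal, a higher number faster removal of the compound. Compound 1 (`C[C@H](Nc1ncnc(N)c1C#N)c1nc2ccc(F)cc2n1-c1ccc(F)cc1`) gives 29.7 mL/min/kg, compound 2 (`C[C@H](Nc1ncnc(N)c1C#N)c1nc2ccc(F)cc2n1-c1cc(F)cc(F)c1`) gives 44 mL/min/kg and compound 3 (`C[C@H](Nc1ncnc(N)c1C#N)c1nc2ccc(F)cc2n1-c1ccccc1`) gives 40.2 mL/min/kg. Compound 3 stands within the scatter of both others, with a 1.1-fold lower number from compound 2 to compound 3 (0.04 log units; within the scatter) and a 1.4-fold higher number from compound 1 to compound 3 (0.13 log units; within the scatter).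

The next structure is compound 4 (`C[C@H](Nc1ncnc(N)c1C#N)c1nc2ccc(F)cc2n1-c1ccccn1`), and the change is pyridin-2-yl in place of phenyl on an aromatic nitrogen. In words, this is pyridin-2-yl in place of phenyl on an aromatic nitrogen. The measured steps that bear on it are changes to the ring on that same nitrogen. Besides the two above, there is a 1.5-fold higher number from compound 1 to compound 2 (0.17 log units; within the scatter). None of the three goes beyond the scatter. Among the measured compounds shown here, none of them puts a nitrogen into that ring, so the data hold no direct precedent for this change. The starting point is therefore compound 3 at 40.2 mL/min/kg, and no step beyond the scatter is expected in this assay. The estimated change is a 1.1-fold lower number from compound 3 to compound 4 (0.04 log units; within the scatter), with its direction left open by the data. For compound 4 the expected clearance is 37 mL/min/kg, with an estimated range from 20 mL/min/kg to 62 mL/min/kg.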

Compound 4, clearance: 16.2 mL/min/kg
Beside the measured number, compound 4's estimate is 2.3-fold (0.36 log units) above it; measured number below the stated range.
By their numbers in this assay, from the lowest: compounds 4, 1, 3 and 2 (each within the scatter of the next, the first and the last beyond it).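

Among the compounds shown here, on the aromatic nitrogen of the shared core, pyridin-2-yl is the first group in this short set to give steps beyond the scatter in this assay (first a 2.5-fold lower number from compound 3 to compound 4 (0.39 log units; beyond the scatter) and then a 2.7-fold lower number from compound 2 to compound 4 (0.43 log units; beyond the scatter)), whereas all the steps among the three carbon-only aryl groups stay within it. The comparison with the 4-fluorophenyl group stays within the scatter (a 1.8-fold lower number from compound 1 to compound 4 (0.26 log units; within the scatter)), so pyridin-2-yl separates from phenyl and 3,5-difluorophenyl but not from 4-fluorophenyl, and any claim of a general gain for the ring nitrogen must name compound 1 as the exception. Nothing available here gives a measured reason for the size of these steps or for the position of compound 1 among them.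

Going by these compounds, it remains open whether the step depends on where the nitrogen sits in the ring, or whether it survives when the pyridin-2-yl ring also carries a fluoro group, a methoxy group or an amine. The compounds shown also leave open whether a non-aromatic group on this nitrogen, such as a cyclohexyl ring, would fall in the same range of clearance.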